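The compounds below may be only part of what the source reports. "The series", "measured", "known", "first", "only" and "open" are said of these compounds alone.

Measured compounds:
- compound 1, `CCOC(=O)c1cccc(-c2ccc(CN(C)C)o2)c1`: 190000 nM
- compound 2, `CCOC(=O)c1cccc(-c2ccc(CN3CCN(C)CC3)o2)c1`: 120000 nM

In an assay on COS-7 cells for inhibition of patatin-like phospholipase domain-containing protein 2 (Mus musculus) (on this read-out higher numbers stand for weaker inhibition and lower numbers for stronger inhibition), compound 1 gives 190000 nM, and compound 2 gives 120000 nM. Among the compounds with values here, the only measured step, a 1.6-fold lower number from compound 1 to compound 2 (0.20 log units; within the scatter), is within the scatter, so the two compounds stand level on this read-out and neither can be called the stronger inhibitor. Compound 3, `CCOC(=O)c1cccc(-c2ccc(CN3CCN(S(C)(=O)=O)CC3)o2)c1`, has not yet been measured. It differs from compound 2 in one place: methylsulfonyl in place of methyl on an amine nitrogen in a ring. Within the data shown here, no measured pair covers an exchange on this ring nitrogen; the step from compound 1 to compound 2 concerns a different part of the amine and was itself flat, so it offers no direction. Compound 3 is therefore expected to stay close to compound 2, with a step of a 1.3-fold higher number from compound 2 to compound 3 (0.10 log units; within the scatter) in this assay. The estimated value of compound 3 is 150000 nM, within a range from 50000 nM to 500000 nM.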

Compound 3, half-maximal inhibitory concentration: 100000 nM
Compound 3: the middle estimate sits 1.5-fold (0.18 log units) above what was measured; low and high end bracket the measured number.
By their numbers in this assay, from the lowest: compounds 3, 2 and 1 (each within the scatter of the next).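

In this assay, methylsulfonyl in place of methyl on the amine nitrogen in the ring gives a 1.2-fold lower number from compound 2 to compound 3 (0.08 log units; within the scatter) and so leaves the two compounds level. Within the data shown here, this is the first reading at this ring nitrogen, and it shows that the number stays within the scatter when a single methyl carbon gives way to the larger methylsulfonyl, which brings hydrogen-bond acceptors that methyl lacks. The exchange of one group says little about the position as a whole, but a substantial change in the group at this nitrogen has not on its own separated these compounds on this read-out.

As far as these compounds go, it remains open whether an acetyl group, a benzyl group or a bare amine hydrogen on this nitrogen would shift the number beyond the scatter. Also open, from the compounds shown here alone, is whether a carboxylic acid in place of the ester on the shared core would do so. Nothing available here explains why this exchange leaves the number level.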